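A second chlorine on the pendant phenyl ring

This account rests on a few compounds, and the source may have more. Where it says the series, first, only, none or still open, it means among the compounds named here.

Measured compounds:
- compound 1, `O=[N+]([O-])c1cc2c(OCCC3CCCCN3)c(-c3cccc(Cl)c3)c(O)nc2cc1Cl`: 40 nM
- compound 2, `O=[N+]([O-])c1cc2c(OCCC3CCCCN3)c(-c3cccc(F)c3)c(O)nc2cc1Cl`: 53 nM
- compound 3, `O=[N+]([O-])c1cc2c(OCCC3CCCCN3)c(-c3ccccc3)c(O)nc2cc1Cl`: 410 nM

Three compounds share one core and differ only in the aromatic group attached to it. In a functional assay on cells (Pituitary gland cell) for antagonist activity at Gonadotropin-releasing hormone receptor (Rattus norvegicus) (on this read-out lower numbers stand for stronger inhibition and higher numbers for weaker inhibition), compound 3 gives 410 nM, the highest number of the three; its nearest neighbour is compound 2 and the furthest is compound 1, both well separated from it. Compound 4, `O=[N+]([O-])c1cc2c(OCCC3CCCCN3)c(-c3cc(Cl)cc(Cl)c3)c(O)nc2cc1Cl`, has not been measured. It differs from compound 3 by 3,5-dichlorophenyl in place of phenyl on an aromatic carbon.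

Among the measured compounds shown here, two measured steps bear on this change, both in the opposite direction. Going a 7.7-fold higher number from compound 2 to compound 3 (0.89 log units; beyond the scatter) and a 10-fold higher number from compound 1 to compound 3 (1.01 log units; beyond the scatter); each removal of a halogen from the phenyl ring pushed the number up well beyond the scatter. Compound 4 adds two chlorines to the phenyl of compound 3, one of which recreates compound 1. For the measured compounds named here, a step at least as large as that from compound 3 to compound 1 is therefore expected in this assay, with the second chlorine perhaps adding a little more, though no measured pair shows the effect of a second halogen. Compound 4 is expected to give 25 nM, in the range 8 nM to 80 nM, a step of a 16-fold lower number from compound 3 to compound 4 (1.21 log units; beyond the scatter).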

Compound 4, half-maximal inhibitory concentration: 24 nM
Compound 4: middle estimate off by 1.0-fold (0.02 log units), on the high side; measured number inside the range.
By their numbers in this assay, from the lowest: compounds 4, 1 and 2 (each within the scatter of the next, the first and the last beyond it); then compound 3.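

In this assay the 3,5-dichlorophenyl group of compound 4 keeps the whole gain over the bare phenyl, with a 17-fold lower number from compound 3 to compound 4 (1.23 log units; beyond the scatter) at this aromatic carbon, so a second chlorine on the ring is tolerated at this place on the shared core. The second chlorine itself cannot be told from the scatter, since a 1.7-fold lower number from compound 1 to compound 4 (0.22 log units; within the scatter) in this read-out and the two compounds therefore take no order, whereas the replacement of 3-fluorophenyl does show a 2.2-fold lower number from compound 2 to compound 4 (0.34 log units; beyond the scatter) as a modest step. Nothing measured here accounts for how halogens on this phenyl ring act on the read-out.

From the compounds shown here alone, it remains open whether the gain belongs to chlorine in particular or would also come with two fluorines in place of the two chlorines of the 3,5-dichlorophenyl group, or with a methoxy or trifluoromethyl group on the phenyl ring. Going by these compounds, all the compounds also carry the same 2-(piperidin-2-yl)ethoxy group, so it is equally open whether these steps would hold with a longer chain or another amine there.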